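One Change, Two Cores: Predicting Compound 4

The source may report more compounds than this note shows. Statements on the series, on what has been measured and on what is new or still open speak of the compounds shown alone.

Compound 1 `COc1ccc(Cn2cc3cc(C(=N)Nc4ccc(N5CCN(C)CC5)cc4)ncc3n2)cc1`: 9900 nM
Compound 2 `Cn1nc(-c2ccccc2)c2cc(C(=N)Nc3ccccc3)ncc21`: 17300 nM
Compound 3 `CN1CCN(c2ccc(NC(=N)c3cc4cn(C)nc4cn3)cc2)CC1`: 24800 nM

All three were tested in a functional assay on PC-3 cells (Homo sapiens) for cytotoxicity, read by MTT assay, with a stated time of 72 h; on this read-out higher numbers stand for weaker inhibition and lower numbers for stronger inhibition. Compound 3 and compound 1 differ in one place, (4-methoxyphenyl in place of hydrogen on a saturated chain carbon bound to an aromatic nitrogen), and that change gave a 2.5-fold lower number from compound 3 to compound 1 (0.40 log units; beyond the scatter). Compound 4 `COc1ccc(Cn2nc(-c3ccccc3)c3cc(C(=N)Nc4ccccc4)ncc32)cc1` carries the same change on the core of compound 2: 4-methoxyphenyl in place of hydrogen on a saturated chain carbon bound to an aromatic nitrogen. The difference between the two cores is not broken down here. Compound 2 and compound 3 lie within the scatter of each other, as do compound 2 and compound 1. For the measured compounds named here, with only one earlier example to rest on, the step for compound 4 is expected to be about a 2.3-fold lower number from compound 2 to compound 4 (0.36 log units; beyond the scatter), because the same change gave a 2.5-fold lower number from compound 3 to compound 1 (0.40 log units; beyond the scatter). Compound 4 is therefore estimated at 7500 nM, between 2500 nM and 20000 nM.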

Compound 4, half-maximal inhibitory concentration: 6300 nM
Compound 4: middle estimate off by 1.2-fold (0.08 log units), on the high side; measured number inside the range.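

In this assay the change gave a 2.7-fold lower number from compound 2 to compound 4 (0.44 log units; beyond the scatter) on a second core. For the compounds shown here, the step matches the earlier one in size: the same change on two cores in this assay, a 2.5-fold lower number (0.40 log units; beyond the scatter) from compound 3 to compound 1 and a 2.7-fold lower number (0.44 log units; beyond the scatter) from compound 2 to compound 4, 1.1-fold (0.04 log units) apart, within the scatter of two such steps This shows that the change kept its size when carried between these two cores, but it rests on only two pairs and does not show why the number falls or whether the step would hold on any other core.

The compounds shown leave open whether a group other than 4-methoxyphenyl at this place, such as an unsubstituted phenyl, a pyridine or a carboxylic acid, would give a step of similar size. They also leave open how much of the step depends on the methoxy group itself.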